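A few compounds are considered here, and "the series" means these few. Any claim that something is new, unique, unknown or untested is made for them only; others in the source may bear on it.

Compound 1 `Cc1ccc(S(=O)(=O)NC2=NCCN2C(=S)SN2CCn3c2nsc3=S)cc1`. In a functional assay on KYSE-510 cells (Homo sapiens) for antiproliferative activity, read by crystal violet staining, with a stated time of 96 h (on this read-out lower numbers stand for stronger inhibition of growth and higher numbers for weaker inhibition of growth), compound 1 gives >= 20000 nM, which is a limit of the assay and not a number.
Compound 2 `COc1cc(C)ccc1S(=O)(=O)NC1=NCCN1C(=S)SN1CCn2c1nsc2=S`. In this assay compound 2 gives >= 20000 nM, also a limit.
Compound 3 `COc1ccc(OC)c(S(=O)(=O)NC2=NCCN2C(=S)SN2CCn3c2nsc3=S)c1`. In this assay compound 3 gives >= 20000 nM, again a limit.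

Compound 3 therefore stands nowhere in particular: it sits at the same limit as the other two, as shown by the limit of >= 20000 nM in this assay, at which 3 of the 3 values shown sit. The steps that lead to it, a step that the two limits leave unreadable from compound 1 to compound 3 and a step that the two limits leave unreadable from compound 2 to compound 3, cannot be read for size or direction, since both ends are limits; the same holds for a step that the two limits leave unreadable from compound 1 to compound 2.

Compound 4 `COc1ccc(S(=O)(=O)NC2=NCCN2C(=S)SN2CCn3c2nsc3=S)cc1OC` differs from compound 3 by 3,4-dimethoxyphenyl in place of 2,5-dimethoxyphenyl on a sulfonyl sulfur. For the measured compounds named here, no measured step bears on this change in a readable way, and nothing among the three values hints at growth inhibition strong enough to fall inside the measurable window. The step of a number no higher from compound 3 to compound 4 (the limit leaves the size open) is therefore expected to be none beyond the scatter. Compound 4 is estimated at 20000 nM, with a range from 8000 nM to 40000 nM, most likely reported again as a limit.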

Compound 4, concentration for 50% growth inhibition: >= 20000 nM
Compound 4 gave a limit, no number; the forecaster's own chance of this, stated with the estimate: 80%; the middle value sits exactly at the limit.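

Compound 4 sits at the same assay limit as compound 1, compound 2 and compound 3, so no step among these four can be read for size or direction: the limit of >= 20000 nM in this assay, at which 4 of the 4 values shown sit.

The compounds shown leave open how these four truly rank, and whether any group on the sulfonyl sulfur would give a measurable number.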